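The source may report more compounds than this note shows. Statements on the series, on what has been measured and on what is new or still open speak of the compounds shown alone.

Of the compounds shown here, two built on a shared core have been measured in an assay on CHO cells for displacement of a labelled ligand from adenosine receptor A1 (Homo sapiens), read by scintillation counting, tested at 10 uM; a lower number here means less inhibition, a higher number more inhibition at the concentration tested (going by the name of the read-out). Compound 1 `CC(C)(C)Cc1c(-c2ccoc2)sc(N)c1C(=O)c1ccc(Cl)cc1` gives 1%. Compound 2 `CC(C)(C)Cc1c(-c2cccs2)sc(N)c1C(=O)c1ccc(Cl)cc1` gives 1%. Within the data shown here, the single step joining them, no change at the digits printed from compound 1 to compound 2 (within the scatter), puts thiophen-2-yl in place of furan-3-yl on an aromatic carbon and leaves the read-out where it was. Compound 2 therefore stands level with compound 1 on the numbers shown, and both sit at the very bottom of the scale, where almost none of the labelled ligand is displaced at the concentration tested.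

Compound 3 `CC(C)(C)Cc1c(-c2ccsc2)sc(N)c1C(=O)c1ccc(Cl)cc1` is the next compound. It differs from compound 2 in one respect: thiophen-3-yl in place of thiophen-2-yl on an aromatic carbon. Among the measured compounds shown here, the only step on record, no change at the digits printed from compound 1 to compound 2 (within the scatter), also exchanged the five-membered aromatic ring on an aromatic carbon of the core. It produced no movement beyond the scatter. With both measured compounds flat at the low end, no step beyond the scatter is expected, so no change at the digits printed from compound 2 to compound 3 (within the scatter) is the estimate. Compound 3 is expected to give about 1% in this assay, within a range from 0% to 10%.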

Compound 3, a percentage reported as inhibition, at one concentration (the size of the read-out at that concentration, not a potency): 2%
Compound 3: middle estimate off by 1 percentage points, on the low side, and the stated range covers the measured number.
By their numbers in this assay, from the lowest: compounds 1, 2 and 3 (each within the scatter of the next).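

In this assay, thiophen-3-yl in place of thiophen-2-yl gives a number 1 percentage points higher from compound 2 to compound 3 (within the scatter), so moving the point of attachment within the same five-membered aromatic ring, with the same atoms joined differently, leaves this read-out within the scatter. The earlier step had exchanged furan-3-yl for thiophen-2-yl, which altered both the ring and its point of attachment, whereas the comparison of thiophen-3-yl with furan-3-yl, a number 1 percentage points higher from compound 1 to compound 3 (within the scatter), keeps the attachment point and exchanges the ring alone, and it too stays within the scatter. At this position on the shared core, then, neither change taken separately moves the read-out, although no measurement here bears on the reason for that.

All three compounds sit at the very bottom of the scale, so these results cannot show whether the three rings would differ under conditions where more of the labelled ligand is displaced. From the compounds shown here alone, it remains open whether a group of another kind at this position, such as a phenyl ring, a chain ending in an amine or a carboxylic acid, would lift the number beyond the scatter.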